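Replacing an Amide Arm with a Methoxyphenyl Group

A few compounds are considered here, and "the series" means these few. Any claim that something is new, unique, unknown or untested is made for them only; others in the source may bear on it.

Two compounds share one core. Compound 1 `CCOC(=O)C1=Cc2ccccc2OC1(OCc1cn(-c2ccc(F)cc2)nn1)C(F)(F)F` gives 8400 nM in a functional assay on HeLa cells (Homo sapiens) for inhibition, read by MTT assay, with a stated time of 24 h (a higher number here means a weaker inhibitor, a lower number a stronger inhibitor), and compound 2 `CCOC(=O)C1=Cc2ccccc2OC1(OCc1cn(CC(=O)Nc2cccc(Cl)c2)nn1)C(F)(F)F` gives 12300 nM; compound 2 stands alongside compound 1, since the step of a 1.5-fold higher number from compound 1 to compound 2 (0.17 log units; within the scatter) lies within the scatter. Compound 3 `CCOC(=O)C1=Cc2ccccc2OC1(OCc1cn(-c2cccc(OC)c2)nn1)C(F)(F)F` differs from compound 2 by 3-methoxyphenyl in place of ((3-chlorophenyl)carbamoyl)methyl on an aromatic nitrogen. Among the measured compounds shown here, only that one step bears on this change, and it was small, so no shift beyond the scatter is expected; the expected step is a 1.4-fold lower number from compound 2 to compound 3 (0.14 log units; within the scatter), because compound 1, which also carries an aromatic ring on that nitrogen, gives 8400 nM. Compound 3 is therefore estimated at 9000 nM, with a range from 3500 nM to 25000 nM.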

Compound 3, half-maximal inhibitory concentration: > 150000 nM
Compound 3 was reported as a limit (the forecaster's own chance of this, stated with the estimate: 10%); middle value at least 16-fold (1.22 log units) away from the limit.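

Compounds 1 and 2 suggested that this nitrogen accepts very different groups, yet a third group separates sharply: in this assay 3-methoxyphenyl gives an at least 12-fold higher number from compound 2 to compound 3 (1.08 log units; beyond the scatter) and an at least 17-fold higher number from compound 1 to compound 3 (1.25 log units; beyond the scatter). Carrying an aromatic ring directly on the nitrogen is therefore not enough to keep the activity of compound 1. The reading for compound 3 is a limit, not a number: the limit of > 150000 nM in this assay, at which 1 of the 3 values shown sits.

On these data alone, whether the loss follows the methoxy group or its place on the phenyl ring stays open. A 4-methoxyphenyl or 3-fluorophenyl group would help separate those two readings.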